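Phenyl to Methyl on a Shared Indole-Linked Core

The source may hold more compounds than are shown below. What is called first, only, known or untested is meant among the compounds shown, and "the series" means these compounds.

Measured compounds:
compound 1 `c1ccc(-c2nnc(-c3c[nH]c4ccccc34)o2)cc1`: > 1000000 nM
compound 2 `COc1cc(-c2nnc(-c3c[nH]c4ccccc34)o2)ccc1O`: > 1000000 nM

In a functional assay on LNCaP cells (Homo sapiens) for cytotoxicity, read by MTT assay (a lower number here means a stronger inhibitor, a higher number a weaker inhibitor), compound 1 gives > 1000000 nM, which is a limit of the assay and not a number. Compound 2 likewise gives only a limit in this assay, namely > 1000000 nM. Compound 1 therefore stands where every shown value stands: the limit of > 1000000 nM in this assay, at which 2 of the 2 values shown sit. Compound 3 `Cc1nnc(-c2c[nH]c3ccccc23)o1` carries the change (methyl in place of phenyl on an aromatic carbon). Going by the values given here, no step between measured compounds is known, so the step from compound 1 to compound 3 in this assay is expected to be none beyond the scatter, at a number no higher from compound 1 to compound 3 (the limit leaves the size open). Compound 3 is estimated at 1000000 nM, with a range from 300000 nM to 3000000 nM, and most likely again only a limit.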

Compound 3, half-maximal inhibitory concentration: > 1000000 nM
Compound 3 was reported as a limit (the forecaster's own chance of this, stated with the estimate: 85%); the middle value lies on the limit itself.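

Going by these compounds alone, compound 1 and compound 3 each give only a limit in this assay, so no step between them can be read: the limit of > 1000000 nM in this assay, at which 3 of the 3 values shown sit.
The compounds shown leave open how strongly any of them acts in this assay and whether methyl and phenyl differ there at all.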